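One Chloro Fewer: From Compound 2 to Compound 3

This account rests on a few compounds, and the source may have more. Where it says the series, first, only, none or still open, it means among the compounds named here.

Compound 1 `CN1CCN(CCCOc2cccc3nc(Nc4ccc(Cl)c(C(F)(F)F)c4)ccc23)CC1` gives 1800 nM in a functional assay on SF-295 cells (Homo sapiens) for inhibition, read by sulforhodamine B assay, with a stated time of 48 h; a lower number here means a stronger inhibitor of growth, a higher number a weaker inhibitor of growth.
Compound 2 `CN1CCN(CCCOc2cccc3nc(Nc4cc(Cl)cc(Cl)c4)ccc23)CC1` gives 1720 nM in this assay.

Going by the values given here, compound 2 carries the lower of the two numbers measured so far, but its nearest neighbour is compound 1 and the step of a 1.0-fold lower number from compound 1 to compound 2 (0.02 log units; within the scatter) lies within the scatter, so the two cannot be told apart. Compound 3 `CN1CCN(CCCOc2cccc3nc(Nc4cccc(Cl)c4)ccc23)CC1` has not yet been measured. It differs from compound 2 by hydrogen in place of chloro on an aromatic carbon; the (3,5-dichlorophenyl)amino group thus becomes (3-chlorophenyl)amino. Among the compounds with values here, only one measured step exists to lean on: a 1.0-fold lower number from compound 1 to compound 2 (0.02 log units; within the scatter) exchanged one substituted phenyl for another and stayed within the scatter. Within the data shown here, no measured pair removes a chloro group from this ring, so the loss of one chlorine is not directly covered. Among the measured compounds shown here, since the one change tried on this ring left the number unmoved, a small step is expected, if any, leaning toward a slightly higher number. Compound 3 is therefore estimated at 2500 nM in this assay, with a range of 1000 nM to 6500 nM. The expected step of a 1.5-fold higher number from compound 2 to compound 3 (0.16 log units; within the scatter) is modest.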

Compound 3, concentration for 50% growth inhibition: 1910 nM
Estimate against measurement, compound 3: 1.3-fold (0.12 log units) above; measured number inside the range.
By their numbers in this assay, from the lowest: compounds 2, 1 and 3 (each within the scatter of the next).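

Taking away one chloro from the 3,5-dichlorophenyl group leaves a 1.1-fold higher number from compound 2 to compound 3 (0.05 log units; within the scatter) in this assay, so on this aromatic carbon, hydrogen and chloro cannot be told apart by this read-out. The comparison with the larger substituent pattern gives the same picture: a 1.1-fold higher number from compound 1 to compound 3 (0.03 log units; within the scatter) shows that the 3-chlorophenyl group also cannot be separated from the 4-chloro-3-(trifluoromethyl)phenyl group, and the three compounds stand level within the scatter. Nothing in the material at hand accounts for this flat result, and no independent measurement bears on it.

All three rings still carry at least one chloro group, so the compounds shown leave open whether an unsubstituted phenyl group would hold the same number in this assay. They also leave open whether a quite different substituent on this ring, such as a methoxy group, a nitrile, an amine or a carboxylic acid, would produce a step beyond the scatter.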